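A few compounds are considered here, and "the series" means these few. Any claim that something is new, unique, unknown or untested is made for them only; others in the source may bear on it.

Three compounds were measured in a functional assay on U-87MG ATCC cells for antiproliferative activity against U-87 MG (Homo sapiens), read by MTT assay, with a stated time of 48 h, tested at 100 uM; a lower number here means a stronger effect, a higher number a weaker effect of the compound at the concentration tested. Compound 1, `COc1ccc(-c2nc(C)c(C(=O)CSc3nc(N)c(C#N)c(-c4ccccc4)n3)s2)cc1`, gives 5.25% in this assay. Compound 2, `COc1ccc(-c2nc(C)c(C(=O)CSc3nc(-c4ccc(OC)cc4)c(C#N)c(=O)[nH]3)s2)cc1`, gives 11.5% in this assay, and compound 3, `COc1ccc(-c2nc(C)c(C(=O)CSc3nc(-c4ccc(OC)c(OC)c4)c(C#N)c(=O)[nH]3)s2)cc1`, gives 5.39% in this assay. Compound 1 and compound 3 lie within the scatter of each other, as do compound 1 and compound 2; the difference between the core of compound 1 and the core of compound 2 is not broken down here.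

Between compound 2 and compound 3 the change is methoxy in place of hydrogen on an aromatic carbon, and the step it made is a number 6.1 percentage points lower from compound 2 to compound 3 (within the scatter), within the scatter. Compound 4, `COc1ccc(-c2nc(C)c(C(=O)CSc3nc(N)c(C#N)c(-c4ccc(OC)cc4)n3)s2)cc1`, is not yet measured; it differs from compound 1 by methoxy in place of hydrogen on an aromatic carbon. This is the same kind of change as from compound 2 to compound 3, but not the same: in compound 4 the entering methoxy sits para to a large group, whereas in compound 3 it sits ortho to a methoxy group and meta to a large group.

The step from compound 1 to compound 4 is expected to be a number 0.8 percentage points higher from compound 1 to compound 4 (within the scatter), of about the same size as the earlier one and within the scatter, which rests on the measured value of compound 1, 5.25%, and on the step from compound 2 to compound 3 staying within the scatter. Compound 4 is therefore estimated to give 6% in this assay, likely between 1% and 14%.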

Compound 4, a percentage reported as activity, at one concentration (the size of the read-out at that concentration, not a potency): 0.26%
Compound 4: the middle estimate sits 5.7 percentage points above what was measured; measured number outside the range, below it.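

On the core of compound 1, methoxy in place of hydrogen, the change from phenyl to 4-methoxyphenyl, gave in this assay a number 5 percentage points lower from compound 1 to compound 4 (within the scatter). Set beside the earlier step on the other core, the change gave two steps that cannot be told apart: the same change on two cores in this assay, a number 6.1 percentage points lower (within the scatter) from compound 2 to compound 3 and a number 5 percentage points lower (within the scatter) from compound 1 to compound 4, 1.1 percentage points apart, within the scatter of two such steps. For the compounds shown here, this shows that, at this single concentration, carrying the change from one core to the other brought no detectable difference in the size of the step, but it does not establish a real effect of methoxy on either core, as each step alone lies within the scatter, and with only two pairs, in which the entering methoxy does not stand in the same place in compound 3 and compound 4, it gives no general rule for the series.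

The compounds shown leave open what other groups would do on this aromatic ring, for example a fluorine, an amine, a carboxylic acid or a longer chain such as ethoxy in place of the methoxy. They also leave open whether the two cores would still respond alike at lower concentrations.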